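Furyl dihydropyrimidinone esters: ester branching at compound 4

The source may hold more compounds than are shown below. What is called first, only, known or untested is meant among the compounds shown, and "the series" means these compounds.

Three compounds of the shared core have numbers in an assay on HeLa cells for displacement of a labelled ligand from adenosine receptor A3 (Homo sapiens), with a stated time of 180 min, tested at 10 uM; a higher number here means more inhibition at the concentration tested (going by the name of the read-out), a lower number less inhibition. Compound 1 `CCCOC(=O)C1=C(C)NC(=O)NC1c1ccco1` gives 2% in this assay. Compound 2 `CCOC(=O)C1=C(CC)NC(=O)NC1c1ccco1` gives 3% in this assay. Compound 3 `CCOC(=O)C1=C(C)N(C)C(=O)NC1c1ccco1` gives 25% in this assay, the highest of the three numbers; the gap to compound 2, the nearest, is beyond the usual scatter, and the gap to compound 1, the furthest, is likewise beyond it. Within the data shown here, compound 3 differs from each of compounds 1 and 2 in more than one place, so no single change can be read off from the measured set, and no step between measured compounds is known.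

Compound 4 `CC1=C(C(=O)OC(C)C)C(c2ccco2)NC(=O)N1C` is the next entry, not yet measured. It differs from compound 3 by methyl in place of hydrogen on a saturated chain carbon bound to an oxygen next to a carbonyl group and a saturated chain carbon. The change is small in count and lies on the ester rather than at the ring nitrogen, where compound 3 differs from the two weaker entries. From compound 3 to compound 4 the step is expected to be small, most likely a modest fall in inhibition or none beyond the scatter, a number 5 percentage points lower from compound 3 to compound 4 (within the scatter). For compound 4 the estimated value in this assay is 20%, with an expected range from 5% to 40%.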

Compound 4, a percentage reported as inhibition, at one concentration (the size of the read-out at that concentration, not a potency): 18%
Estimate against measurement, compound 4: 2 percentage points above; the measured number falls inside the stated range.
By their numbers in this assay, from the lowest: compounds 1 and 2 (each within the scatter of the next); then compounds 4 and 3 (each within the scatter of the next).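

In this assay, among these compounds, the change from ethoxycarbonyl to isopropoxycarbonyl gives a number 7 percentage points lower from compound 3 to compound 4 (within the scatter) and is the first step that can be read at a single place, since the earlier compounds offered no pair differing in one place. At this position, a saturated chain carbon bound to an oxygen next to a carbonyl group and a saturated chain carbon, methyl in place of hydrogen therefore leaves the reading of inhibition at the tested concentration indistinguishable from that of compound 3, so this one added carbon on the ester gives no measurable separation. Nothing available on the compounds accounts for this outcome or says what the step means beyond the number itself.

Only one small branching step is shown, on a single background, so it stays open whether the same ethyl to isopropyl change would read alike on other members of the shared core. Also open, going by these compounds, is whether a larger ester group such as tert-butyl or benzyl, a longer chain on the ester oxygen, or a carboxylic acid in place of the ester would move the number beyond the scatter.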